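A few compounds are considered here, and "the series" means these few. Any claim that something is new, unique, unknown or untested is made for them only; others in the source may bear on it.

Compound 1 `CC(=O)Oc1ccccc1C(=O)O[C@H]1CO[C@H]2[C@@H]1OC[C@H]2OC(=O)c1ccc(O)cc1` and compound 2 `CCCCC(=O)O[C@@H]1CO[C@H]2[C@@H]1OC[C@@H]2OC(=O)c1ccccc1OC(C)=O` share one core, each carrying two acyl groups. In an ADME assay on a cell-free system (plasma, Homo sapiens) for metabolic stability, with Plasma (Rattus norvegicus) as the target, read by HPLC, at pH 7.4 (on this read-out higher numbers stand for a longer-lived compound and lower numbers for a shorter-lived compound), compound 1 gives 0.0198 h, and in this assay compound 2 gives 0.0198 h. Going by the values given here, the step between them, no change at the digits printed from compound 1 to compound 2 (within the scatter), left the half-life where it was, so compound 2 stands level with compound 1 on the numbers measured so far.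

Compound 3 `CC(=O)Oc1ccccc1C(=O)O[C@H]1CO[C@H]2[C@@H]1OC[C@H]2OC(=O)c1ccccc1C` has not yet been measured in this assay. It differs from compound 2 in one place: 2-methylphenyl in place of butyl on a carbonyl carbon. Among the compounds with values here, the only measured step that bears on this position is no change at the digits printed from compound 1 to compound 2 (within the scatter), in which 4-hydroxyphenyl gave way to butyl on the same carbonyl carbon without moving the half-life. The change now in hand runs the other way, from butyl back to an aromatic group, 2-methylphenyl. Within the data shown here, with the one available step showing no movement, compound 3 is expected to stay level with compound 2, a step of a 1.0-fold higher number from compound 2 to compound 3 (0.00 log units; within the scatter). Compound 3 is therefore estimated at 0.02 h, within a range from 0.01 h to 0.04 h.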

Compound 3, half-life: 0.035 h
Estimate against measurement, compound 3: 1.8-fold (0.24 log units) below, within the range that was stated.
By their numbers in this assay, from the lowest: compounds 1, 2 and 3 (each within the scatter of the next).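

The carbonyl carbon has now carried three different groups, one chain and two aromatic rings, and in this assay no exchange among them has moved the half-life beyond the scatter. The earlier compounds shown here offered only the exchange of 4-hydroxyphenyl for butyl, whereas 2-methylphenyl can now be read against both of those groups: in place of butyl it gives a step within the scatter (a 1.8-fold higher number from compound 2 to compound 3 (0.25 log units; within the scatter)), and in place of 4-hydroxyphenyl it gives another (a 1.8-fold higher number from compound 1 to compound 3 (0.25 log units; within the scatter)). The data therefore show that a methyl-bearing aromatic ring at this position fits the same band as the other two groups, and no measurement at hand accounts for how closely these half-lives lie together.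

The compounds shown leave open whether an amine, a carboxylic acid or a longer chain on the same carbonyl carbon would stay within that band. They also leave open what happens when the other acyl group, which all three compounds share, gives way to a different one, such as a simple phenyl group without its acetyl-bearing oxygen.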